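The source may report more compounds than this note shows. Statements on the series, on what has been measured and on what is new or still open speak of the compounds shown alone.

The three measured compounds share one sugar-bearing core and differ in the group attached to it. Among the compounds with values here, compound 1 `C#Cc1cn([C@@H]2O[C@H](CO)[C@@H](O)[C@H]2O)c2ncnc(C)c12` is the only one that gives a number: in an ADME assay on MRC5 cells (Homo sapiens), read by MTT assay, with a stated time of 72 h (a lower number here means a stronger inhibitor, a higher number a weaker inhibitor), compound 1 gives 1440 nM. Compound 2 `O=c1[nH]cnc2c1c(-c1cccs1)cn2[C@@H]1O[C@H](CO)[C@@H](O)[C@H]1O` does not reach a number. In this assay compound 2 gives > 100000 nM, which is a limit of the assay rather than a measured value. Compound 3 `Cc1nc(N)c2c(-c3ccccc3)cn([C@@H]3O[C@H](CO)[C@@H](O)[C@H]3O)c2n1` is the same kind of case. In this assay compound 3 gives > 100000 nM, again a limit of the assay and not a number. Compound 3 therefore stands at the limit of > 100000 nM in this assay, at which 2 of the 3 values shown sit.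

Compound 4 `Cc1nc(N)c2c(-c3ccco3)cn([C@@H]3O[C@H](CO)[C@@H](O)[C@H]3O)c2n1` differs from compound 3 in one place: furan-2-yl in place of phenyl on an aromatic carbon. Within the data shown here, no measured pair of this kind is available, so the size of the step cannot be read from the data. Because compound 3 sits at the limit of > 100000 nM in this assay, at which 2 of the 3 values shown sit, the step in this assay is expected to be a number no higher from compound 3 to compound 4 (the limit leaves the size open), that is, nothing beyond the usual scatter, with no direction claimed. Compound 4 is expected to give about 100000 nM in this assay, most likely reported once more as a limit, with the estimate spanning from 30000 nM to 300000 nM.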

Compound 4, half-maximal inhibitory concentration: > 100000 nM
Compound 4: a limit, no number; the forecaster's own chance of this, stated with the estimate: 70%; the middle value lies on the limit itself.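

Within the data shown here, compound 3 and compound 4 both stop at a limit of this assay and not at a number, so no step from one to the other can be read: the limit of > 100000 nM in this assay, at which 3 of the 4 values shown sit. The compounds shown leave open whether furan-2-yl and phenyl on the shared core differ at all in this assay and, if they do, by how much.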